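A few compounds are considered here, and "the series" means these few. Any claim that something is new, unique, unknown or untested is made for them only; others in the source may bear on it.

Notes on the series. Activity is read in a functional assay on the whole organism (strain Wistar) for inhibition, with Rattus norvegicus as the target, read by paw edema, with stated times of 2 h and 1 h, at a dose of 6 mg/kg by the oral route; a higher number here means more inhibition at the dose given (going by the name of the read-out), a lower number less inhibition. Compound 1 `COc1ccccc1-c1cc(=O)[nH]n1-c1ccc(C(=O)NNC(=O)CO[N+](=O)[O-])cc1` gives 55.7% in this assay. Within the data shown here, compound 2 `O=C(CO[N+](=O)[O-])NNC(=O)c1ccc(-n2[nH]c(=O)cc2-c2ccccc2O)cc1` gives 19.3% in this assay, the lowest of the two numbers measured so far; the nearest is compound 1, which stands beyond the scatter above it. Among the measured compounds shown here, the single measured step, a number 36.4 percentage points lower from compound 1 to compound 2 (beyond the scatter), came with hydrogen in place of methyl on an oxygen on an aromatic ring.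

Compound 3 `O=C(CO[N+](=O)[O-])NNC(=O)c1ccc(-n2[nH]c(=O)cc2-c2ccccc2)cc1` has not yet been measured in this assay. It differs from compound 2 as follows: hydrogen in place of hydroxy on an aromatic carbon. For the measured compounds named here, no measured step removes the hydroxy group outright, so the step from compound 1 to compound 2 bears on this one only loosely: it shows that altering this group shifts the number by a large amount, without telling the direction of a further change. With only that to go on, compound 3 is estimated at about 32%, with a range from 12% to 55%. The expected step is a number 12.7 percentage points higher from compound 2 to compound 3 (beyond the scatter), a rise that may or may not clear the scatter.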

Compound 3, a percentage reported as inhibition, in the whole organism at one dose (the size of the read-out at that dose, not a potency): 16.1%
For compound 3 the middle estimate is 15.9 percentage points above the measured one; the range from low to high includes it.
By their numbers in this assay, from the lowest: compounds 3 and 2 (each within the scatter of the next); then compound 1.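

Taking the hydroxy group off, 2-hydroxyphenyl to phenyl, gives (a number 3.2 percentage points lower from compound 2 to compound 3 (within the scatter)) in this assay, so at this place, ortho to a large group, this read-out does not separate hydroxy from hydrogen. Methoxy at the same place does stand apart, with (a number 39.6 percentage points lower from compound 1 to compound 3 (beyond the scatter)), and the large earlier step, (a number 36.4 percentage points lower from compound 1 to compound 2 (beyond the scatter)), therefore reads within these three compounds as a higher number that goes with methoxy rather than a loss that goes with hydroxy. Nothing at hand accounts for why methoxy alone separates from the other two.

Open, going by these compounds, is whether the higher number belongs to methoxy itself or would come with other groups on this aromatic carbon, such as an ethoxy group, a methyl group or a chlorine atom. Also open is whether methoxy would keep its place in the order on another carbon of this ring, and since each number comes from a single dose, the compounds shown give no potency.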